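This account rests on a few compounds, and the source may have more. Where it says the series, first, only, none or still open, it means among the compounds named here.

Measured so far:
- compound 1, `CCN1CCc2c(c(C)nn2C(=O)Nc2cc(C)ccc2C)C1`, gives 2.6%
- compound 2, `CCN1CCc2c(c(C(C)(C)C)nn2C(=O)Nc2c(C)cccc2C)C1`, gives 15.7%

In a functional assay on the whole organism (strain Swiss albino) for inhibition, with Mus musculus as the target, in the formalin test, with stated times of 30 min and 5 min, at a dose of 100 mg/kg (a higher number here means more inhibition at the dose given (going by the name of the read-out), a lower number less inhibition), compound 2 gives 15.7% and stands highest of the two numbers; compound 1 gives 2.6%, a gap that lies beyond the usual scatter. Among the compounds with values here, compound 1 and compound 2 differ in two places at once, so what the two values show is only that the pair is set apart; no single change can be credited.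

Compound 3 `CCN1CCc2c(c(C(C)(C)C)nn2C(=O)Nc2cc(C)ccc2C)C1` has not yet been measured. It keeps the core and the tert-butyl group of compound 2 and differs from it in one place: 2,5-dimethylphenyl in place of 2,6-dimethylphenyl on an amide-type nitrogen. Within the data shown here, the aromatic ring that enters is the one carried by compound 1. Among the measured compounds shown here, no measured pair isolates this exchange, so the size of its effect is unknown. Compound 1 carries the same 2,5-dimethylphenyl group and gives 2.6%; on that ground a downward step is expected. The step from compound 2 to compound 3 is expected to be a number 7.7 percentage points lower from compound 2 to compound 3 (within the scatter), though it may stay within the scatter. Compound 3 is expected to give 8%, in the range 0% to 20%.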

Compound 3, a percentage reported as inhibition, in the whole organism at one dose (the size of the read-out at that dose, not a potency): 0%
The estimate for compound 3 lay 8 percentage points above the measured number; the range from low to high includes it.
By their numbers in this assay, from the lowest: compounds 3 and 1 (each within the scatter of the next); then compound 2.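

In this assay, 2,5-dimethylphenyl in place of 2,6-dimethylphenyl on the amide-type nitrogen gives a number 15.7 percentage points lower from compound 2 to compound 3 (beyond the scatter), so this single exchange, which keeps the same atoms but joins them differently, is enough on its own to produce a step beyond the scatter, something the earlier pair, differing in two places at once, could not show. With 2,5-dimethylphenyl held constant, tert-butyl in place of methyl on an aromatic carbon gives a number 2.6 percentage points lower from compound 1 to compound 3 (within the scatter), so with this aromatic group the size of that carbon's substituent makes no difference that can be told from the scatter. Nothing available explains why the two dimethylphenyl groups part ways in this test.

The compounds shown leave open whether tert-butyl and methyl would also stay within the scatter of each other when the group on the nitrogen is 2,6-dimethylphenyl, since the tert-butyl result so far rests on a single aromatic group. They also leave open how a plain phenyl ring or a pyridine ring on that nitrogen would compare, and whether any such group could lift the inhibition well above that of compound 2, which gives 15.7%.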